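Cytotoxicity of Three Cyanoacrylamides and an Unmeasured Fourth

The source may report more compounds than this note shows. Statements on the series, on what has been measured and on what is new or still open speak of the compounds shown alone.

Compound 1 `COc1cc(NC(=O)/C(C#N)=C/c2ccccc2C(F)(F)F)cc(OC)c1OC`, compound 2 `COc1ccc(NC(=O)/C(C#N)=C/c2ccccc2C(F)(F)F)cc1OC` and compound 3 `COc1ccccc1NC(=O)/C(C#N)=C/c1ccc(OC)c(OC)c1` share an acrylamide bearing a nitrile and a trifluoromethyl or methoxy pattern spread across two aromatic rings. All three were tested in an ADME assay on HBZY-1 cells (Rattus norvegicus) for cytotoxicity, read by MTT assay, with a stated time of 2 h; on this read-out higher numbers stand for weaker inhibition and lower numbers for stronger inhibition. In this assay compound 1 gives > 200000 nM, which is a limit of the assay rather than a number. Compound 2 likewise gives > 200000 nM, again a limit. Compound 3 gives > 200000 nM, also a limit. Compound 1 differs from compound 2 by one change, (methoxy in place of hydrogen on an aromatic carbon). The step that the two limits leave unreadable from compound 2 to compound 1 cannot be sized because the limit of > 200000 nM in this assay, at which 3 of the 3 values shown sit, holds both of its ends. Compound 3 differs from compound 2 in its core, and the difference between the two cores is not broken down here.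

The unmeasured compound 4 `COc1ccccc1NC(=O)/C(C#N)=C/c1cc(OC)c(OC)c(OC)c1` stands to compound 3 exactly as compound 1 stands to compound 2: the same change, (methoxy in place of hydrogen on an aromatic carbon), at a place described in the same words. Its outcome is therefore expected to look like the one already seen. That expectation rests on (the limit of > 200000 nM in this assay, at which 3 of the 3 values shown sit), where compound 1 sits after this same change. The step that the estimate means, a step that the limit leaves unreadable from compound 3 to compound 4, is expected to be small. Compound 4 is expected to give 300000 nM in this assay, most likely as another limit.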

Compound 4, half-maximal inhibitory concentration: > 200000 nM
Compound 4 was reported as a limit; the forecaster's own chance of this, stated with the estimate: 90%; the middle value lies beyond the limit too.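

No size can be read for the step from compound 3 to compound 4, as each compound's value is a limit of the assay and not a number: the limit of > 200000 nM in this assay, at which 4 of the 4 values shown sit.

The compounds shown leave open at what concentration, if any, each would show an effect in this assay and whether methoxy in place of hydrogen would shift that concentration.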